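This account rests on a few compounds, and the source may have more. Where it says the series, first, only, none or still open, it means among the compounds named here.

Three analogues share a core in which a benzofuran-derived hydrazone is joined to a 2-aminothiazole; compound 1 `C/C(=N\Nc1nc(-c2ccc(C)cc2)cs1)c1cc2ccccc2o1` carries a 4-methylphenyl, compound 2 `COc1ccc(-c2csc(N/N=C(\C)c3cc4ccccc4o3)n2)cc1` a 4-methoxyphenyl and compound 3 `CCOC(=O)Cc1csc(N/N=C(\C)c2cc3ccccc3o2)n1` an (ethoxycarbonyl)methyl on the thiazole. In a functional assay on HepG2 cells (Homo sapiens) for antiproliferative activity (a higher number here means a weaker inhibitor, a lower number a stronger inhibitor), compound 1 gives 14100 nM, compound 2 gives 15700 nM and compound 3 gives 7740 nM. Between the two aryl analogues a 1.1-fold higher number from compound 1 to compound 2 (0.05 log units; within the scatter). Toward compound 3 the picture is a 1.8-fold lower number from compound 1 to compound 3 (0.26 log units; within the scatter) and a 2.0-fold lower number from compound 2 to compound 3 (0.31 log units; beyond the scatter), so compound 3 is set apart from compound 2 only.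

Compound 4 `C/C(=N\Nc1nc(C)cs1)c1cc2ccccc2o1` differs from compound 3 by hydrogen in place of ethoxycarbonyl on a saturated chain carbon bound to an aromatic carbon. Within the data shown here, no measured step removes an ethoxycarbonyl; the two steps that end at compound 3 replace an aryl ring with the ester-bearing chain and are small. Compound 4 is estimated at 10000 nM, with a range from 4000 nM to 25000 nM. That corresponds to an expected 1.3-fold higher number from compound 3 to compound 4 (0.11 log units; within the scatter), within or at the edge of the scatter.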

Compound 4, half-maximal inhibitory concentration: 4000 nM
The estimate for compound 4 lay 2.5-fold (0.40 log units) above the measured number, within the range that was stated.
By their numbers in this assay, from the lowest: compounds 4, 3, 1 and 2 (each within the scatter of the next, the first and the last beyond it).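

The step of a 1.9-fold lower number from compound 3 to compound 4 (0.29 log units; within the scatter) shows that in this assay the ethoxycarbonyl on a saturated chain carbon bound to an aromatic carbon can go without a change that stands clear of the scatter, so (ethoxycarbonyl)methyl and methyl cannot be told apart here. The earlier compounds shown here separated the ester-bearing chain from only one of the two aryl analogues, whereas methyl stands apart from both, with a 3.9-fold lower number from compound 2 to compound 4 (0.59 log units; beyond the scatter) and with a 3.5-fold lower number from compound 1 to compound 4 (0.55 log units; beyond the scatter) as well. Among these four compounds, then, the smallest group gives a number clearly lower than either aryl group does, while compound 3 lies within the scatter of compound 4 and of compound 1.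

On these data alone, whether a carboxylic acid, a primary amide or a longer alkyl chain at this place would stand with compound 4 or with the aryl analogues remains open. Why the methyl and aryl compounds differ also stays unsettled, as no independent measurement bears on this result.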